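Swapping Chloro for Fluoro on Compound 2

The compounds below may be only part of what the source reports. "The series", "measured", "known", "first", "only" and "open" are said of these compounds alone.

Compound 2 `NC(=O)N1CCN(C(=S)SCc2cn(Cc3ccc(F)cc3)nn2)CC1` is the reference point. In a functional assay on MCF7 cells (Homo sapiens) for cytotoxicity, read by MTT assay, with a stated time of 72 h (a higher number here means a weaker inhibitor, a lower number a stronger inhibitor), compound 2 gives 22100 nM, the highest of the two numbers measured outright; the nearest is compound 3 `CCN(C)C(=O)N1CCN(C(=S)SCc2cn(Cc3ccc(F)cc3)nn2)CC1`, which in this assay gives 2150 nM. Compound 1 `NC(=O)N1CCN(C(=S)SCc2cn(Cc3ccccc3F)nn2)CC1` in this assay reaches only a limit, > 128000 nM, as noted in the limit of > 128000 nM in this assay, at which 1 of the 3 values shown sits. Two measured steps are known: an at least 5.7-fold lower number from compound 1 to compound 2 (0.76 log units; beyond the scatter), and a 10-fold lower number from compound 2 to compound 3 (1.01 log units; beyond the scatter). Compound 4 `NC(=O)N1CCN(C(=S)SCc2cn(Cc3ccc(Cl)cc3)nn2)CC1` differs from compound 2 by chloro in place of fluoro on an aromatic carbon. Neither measured step concerns this change directly: one relocates a fluorine on the ring, the other alters the substituent on the carbonyl carbon, so neither offers a guide to exchanging one halogen for another at the same spot. The step is therefore expected to be small, likely within the scatter, and if anything toward a lower number: a 1.5-fold lower number from compound 2 to compound 4 (0.17 log units; within the scatter). Compound 4 is expected to give 15000 nM in this assay, within 5000 nM to 45000 nM.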

Compound 4, half-maximal inhibitory concentration: > 128000 nM
Compound 4 ended at the assay's limit (the forecaster's own chance of this, stated with the estimate: 5%); at least 8.5-fold (0.93 log units) between middle value and limit.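

Compound 2 proves sensitive to the identity of the halogen, not only to where it sits on the ring: in this assay chloro in place of fluoro gives an at least 5.7-fold higher number from compound 2 to compound 4 (0.76 log units; beyond the scatter). The earlier compounds had shown only a change of the fluorine's place, and among the compounds with amino on the carbonyl carbon, compound 2 alone now gives a number rather than a limit. Compound 1 and compound 4 both stand at a limit, so the step between them cannot be read: the limit of > 128000 nM in this assay, at which 2 of the 4 values shown sit.

The compounds shown leave open whether ethyl(methyl)amino on the carbonyl carbon, as in compound 3, would keep a measurable number with 4-chlorophenyl in place of 4-fluorophenyl. They also leave open how a methoxy group, a nitrile or plain hydrogen would read on this aromatic carbon.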